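This account rests on a few compounds, and the source may have more. Where it says the series, first, only, none or still open, it means among the compounds named here.

Compound 1 `CCCS(=O)(=O)N1CCN(c2ccc(OCC3CCN(C(=O)CC(C)C)CC3)cn2)CC1` — 1600 nM
Compound 2 `CCCS(=O)(=O)N1CCN(c2ccc(OCC3CCN(C(=O)CC(C)(C)C)CC3)cn2)CC1` — 2800 nM
Compound 3 `CCS(=O)(=O)N1CCN(c2ccc(OCCC3CCN(C(=O)OC(C)C)CC3)cn2)CC1` — 1200 nM

All three numbers come from a functional assay on CHO-K1 cells for agonist activity at Glucose-dependent insulinotropic receptor (Homo sapiens), read by a luciferase reporter, with a stated time of 5 h; a higher number here means that more compound is needed for the effect, a lower number that less compound is needed. Compound 1 and compound 2 share one core and differ only by methyl in place of hydrogen on a saturated chain carbon bound to three saturated chain carbons; that step reads a 1.8-fold higher number from compound 1 to compound 2 (0.24 log units; within the scatter). Compound 3 rests on a different core, and the difference between the two cores is not broken down here; the value of compound 3 lies within the scatter of compound 1, while the gap to compound 2 lies beyond it.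

Compound 4 `CCCS(=O)(=O)N1CCN(c2ccc(OCCC3CCN(C(=O)OC(C)C)CC3)cn2)CC1` has not yet been measured. It differs from compound 3 by methyl in place of hydrogen on a saturated chain carbon, two bonds along the chain from a sulfonyl sulfur. For the measured compounds named here, this is the same kind of change as the one from compound 1 to compound 2, but not the same: there the place was on a saturated chain carbon bound to three saturated chain carbons, here it is on a saturated chain carbon, two bonds along the chain from a sulfonyl sulfur. Because a 1.8-fold higher number from compound 1 to compound 2 (0.24 log units; within the scatter) lay within the scatter, only a small step is expected here as well, namely a 1.3-fold higher number from compound 3 to compound 4 (0.10 log units; within the scatter) in this assay. For compound 4 the estimate is 1500 nM, with a likely range from 600 nM to 4000 nM.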

Compound 4, half-maximal effective concentration: 700 nM
Compound 4: middle estimate off by 2.1-fold (0.33 log units), on the high side; measured number inside the range.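

Changing ethylsulfonyl to propylsulfonyl in this assay gives a 1.7-fold lower number from compound 3 to compound 4 (0.23 log units; within the scatter), and each step alone is small, but the comparison with the earlier methyl step shows that the two do not match: the same change on two cores in this assay, a 1.8-fold higher number (0.24 log units; within the scatter) from compound 1 to compound 2 and a 1.7-fold lower number (0.23 log units; within the scatter) from compound 3 to compound 4, 3.0-fold (0.48 log units) apart, beyond the scatter of two such steps

So in this series, methyl in place of hydrogen cannot be treated as a fixed shift that carries unchanged from one core to another. These data do not show what sets the two steps apart, since the methyl sits at a different place in each pair as well as on a different core, and a single pair on each side cannot separate those two differences.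

The compounds shown leave open how the ethylsulfonyl counterpart of compound 1 would read, which would place the same change at the same position on both cores. They also leave open whether a longer chain on the sulfonyl, such as butyl, would read differently from propyl on the core of compound 4.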